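The source may hold more compounds than are shown below. What is called first, only, known or untested is meant among the compounds shown, and "the series" means these compounds.

Measured compounds:
compound 1, `CC(C)=CCC/C(C)=C/CC/C(C)=C/CC[C@@H]1[C@@]2(C)CC/C(=N\OCc3cn(-c4ccccc4)nn3)C(C)(C)[C@@H]2CC[C@@]1(C)O`: 6160 nM
compound 2, `CC(C)=CCC/C(C)=C/CC/C(C)=C/CC[C@@H]1[C@@]2(C)CC/C(=N\OCc3cn(-c4ccccc4C#N)nn3)C(C)(C)[C@@H]2CC[C@@]1(C)O`: 20000 nM
compound 3, `CC(C)=CCC/C(C)=C/CC/C(C)=C/CC[C@@H]1[C@@]2(C)CC/C(=N\OCc3cn(-c4ccncc4)nn3)C(C)(C)[C@@H]2CC[C@@]1(C)O`: 13000 nM

All three were tested in a functional assay on A549 cells (Homo sapiens) for cytotoxicity, read by MTT assay, with a stated time of 48 h; on this read-out lower numbers stand for stronger inhibition and higher numbers for weaker inhibition. Compound 1 gives the lowest number of the three in this assay, with compound 3 nearest and compound 2 furthest from it. The two changes already tried on the aromatic ring attached to the triazole both raised the number: a 3.2-fold higher number from compound 1 to compound 2 (0.51 log units; beyond the scatter) and a 2.1-fold higher number from compound 1 to compound 3 (0.32 log units; beyond the scatter).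

Compound 4, `CC(C)=CCC/C(C)=C/CC/C(C)=C/CC[C@@H]1[C@@]2(C)CC/C(=N\OCc3cn(-c4ccc(F)c(F)c4F)nn3)C(C)(C)[C@@H]2CC[C@@]1(C)O`, has not yet been measured in this assay. It differs from compound 1 in one place: 2,3,4-trifluorophenyl in place of phenyl on an aromatic nitrogen. For the measured compounds named here, no measured step introduces fluorine, so the two steps from compound 1 bear on it only loosely, as examples of substitution or replacement on that ring, and both were modest and in the weakening direction. A modest rise beyond the scatter is therefore expected, a 1.8-fold higher number from compound 1 to compound 4 (0.25 log units; within the scatter). Compound 4 is estimated at 11000 nM in this assay, with a likely range of 4500 nM to 27000 nM.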

Compound 4, half-maximal inhibitory concentration: 26900 nM
Beside the measured number, compound 4's estimate is 2.4-fold (0.39 log units) below it; low and high end bracket the measured number.
By their numbers in this assay, from the lowest: compound 1; then compounds 3, 2 and 4 (each within the scatter of the next, the first and the last beyond it).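

In this assay, putting three fluorine atoms on the phenyl group raises the number as well (in the step of a 4.4-fold higher number from compound 1 to compound 4 (0.64 log units; beyond the scatter)), so compound 1 keeps the lowest number after a third change at this position. The 2,3,4-trifluorophenyl group is separated from the pyridin-4-yl group (in the step of a 2.1-fold higher number from compound 3 to compound 4 (0.32 log units; beyond the scatter)) but not from the 2-cyanophenyl group (in the step of a 1.3-fold higher number from compound 2 to compound 4 (0.13 log units; within the scatter)), so those two substituted phenyl groups cannot be told apart here. Nothing available accounts for these differences.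

Going by these compounds, whether a single fluorine on the phenyl group would give the same rise remains open, as does the contribution of each of the three fluorine atoms. On these data alone, what an amine, a carboxylic acid or a cyclohexyl group would do at this position is also open.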